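The compounds below may be only part of what the source reports. "The series", "measured", "known", "first", "only" and "open" are said of these compounds alone.

Measured so far:
compound 1 `O=S(=O)(Nc1ccc(-c2nc3ccccc3o2)cc1)c1ccc(F)c(C(F)(F)F)c1` — 28000 nM
compound 2 `O=S(=O)(Nc1ccc2oc(-c3ccccc3)nc2c1)c1ccc(Cl)c(Cl)c1` — > 100000 nM
compound 3 `O=S(=O)(Nc1ccc2oc(-c3ccccc3)nc2c1)c1ccc(Cl)c(C(F)(F)F)c1` — > 100000 nM

In an assay on cells for inhibition of HSP60/HSP10 (Homo sapiens), with a stated time of 60 min (on this read-out lower numbers stand for stronger inhibition and higher numbers for weaker inhibition), compound 1 gives 28000 nM. Compound 2 reaches only a limit of the assay, > 100000 nM. Compound 3 likewise returns only a limit, > 100000 nM. Among the measured compounds shown here, the single measured step, a step that the two limits leave unreadable from compound 2 to compound 3, is therefore of unknown size and direction, both ends resting on (the limit of > 100000 nM in this assay, at which 2 of the 3 values shown sit). Compound 2 thus stands at the edge of what the assay reports, with no number of its own.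

Compound 4 `Cc1cccc(S(=O)(=O)Nc2ccc3oc(-c4ccccc4)nc3c2)c1` has not been measured. Its difference from compound 2 is 3-methylphenyl in place of 3,4-dichlorophenyl on a sulfonyl sulfur. For the measured compounds named here, no measured step covers this change: the step from compound 2 to compound 3 concerns a trifluoromethyl in place of a chloro and is itself unreadable, and compound 1 belongs to a differently arranged core, so its value offers no step to compound 2. The data therefore give no direction for this assay beyond what compound 2 itself shows, and a limit again is the most likely outcome.

Compound 4 is expected to give about 90000 nM in this assay, within 20000 nM to 400000 nM. The step of an at least 1.1-fold lower number from compound 2 to compound 4 (0.04 log units; that floor lies within the scatter) is expected to be no more than the scatter, with a substantial chance that only a limit is reported.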

Compound 4, half-maximal inhibitory concentration: > 100000 nM
Compound 4 was reported as a limit; the forecaster's own chance of this, stated with the estimate: 60%; at least 1.1-fold (0.04 log units) between middle value and limit.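

Compound 2 and compound 4 both return only a limit in this assay, so no step between them can be read, and the series stays where it was: the limit of > 100000 nM in this assay, at which 3 of the 4 values shown sit.

Still open, going by these compounds, is whether 3-methylphenyl in place of 3,4-dichlorophenyl on a sulfonyl sulfur changes inhibition at all, as compound 2, compound 3 and compound 4 have no numerical value.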